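The source may report more compounds than this note shows. Statements on the series, on what has been measured and on what is new or still open speak of the compounds shown alone.

Measured so far: compound 1 `CCCCCCNS(=O)(=O)NC(=O)Nc1c(C(C)C)cccc1C(C)C` gives 8100 nM in an assay on liver for inhibition of sterol O-acyltransferase 1 (Rattus norvegicus), using microsomes; on this read-out higher numbers stand for weaker inhibition and lower numbers for stronger inhibition. Compound 2 `CC(C)c1cccc(C(C)C)c1OC(=O)NS(=O)(=O)N1CCCCC1` has only a limit in this assay.

In this assay compound 2 sits at the assay limit, > 100000 nM, which is a limit and not a number (the limit of > 100000 nM in this assay, at which 1 of the 2 values shown sits). Compound 3 `CCCCCCNS(=O)(=O)NC(=O)Oc1c(C(C)C)cccc1C(C)C` differs from compound 2 by hexylamino in place of piperidin-1-yl on a sulfonyl sulfur. Because compound 1, which carries the same hexylamino group, gives 8100 nM, some gain is expected. Compound 3 is therefore estimated at 30000 nM, with a range from 8000 nM to 100000 nM. The expected step is an at least 3.3-fold lower number from compound 2 to compound 3 (0.52 log units; beyond the scatter), though a limit may again be reported.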

Compound 3, half-maximal inhibitory concentration: 21000 nM
The estimate for compound 3 lay 1.4-fold (0.15 log units) above the measured number; low and high end bracket the measured number.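

On the sulfonyl sulfur, hexylamino in place of piperidin-1-yl gives a measurable number in this assay, with an at least 4.7-fold lower number from compound 2 to compound 3 (0.67 log units; beyond the scatter). This is the first comparison at this position, and its size is only a minimum, since compound 2 has a limit and not a number: the limit of > 100000 nM in this assay, at which 1 of the 3 values shown sits.

The compounds shown leave open whether a longer chain such as octylamino, or a dimethylamino group, on the same sulfur would give a lower number. They also cannot separate the effect of opening the ring from that of the hydrogen on the hexylamino nitrogen.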